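Trifluoromethyl for trifluoromethoxy in compound 3

This account rests on a few compounds, and the source may have more. Where it says the series, first, only, none or still open, it means among the compounds named here.

In a functional assay on HeLa cells (Homo sapiens) for inhibition, read by sulforhodamine B assay, with a stated time of 74 h (on this read-out lower numbers stand for stronger inhibition and higher numbers for weaker inhibition), compound 1 `O=C1C=CC2(C=C1)OCC(=O)N2S(=O)(=O)c1ccccc1` gives only a limit, > 10000 nM. Within the data shown here, compound 2 `Cc1ccccc1S(=O)(=O)N1C(=O)COC12C=CC(=O)C=C2` reaches 3720 nM, and compound 3 `O=C1C=CC2(C=C1)OCC(=O)N2S(=O)(=O)c1ccccc1OC(F)(F)F` reaches 140 nM, the lowest number measured so far. Compound 4 `O=C1C=CC2(C=C1)OCC(=O)N2S(=O)(=O)c1ccccc1C(F)(F)F` has trifluoromethyl in place of trifluoromethoxy on an aromatic carbon, ortho to a large group, and the change is trifluoromethyl in place of trifluoromethoxy on an aromatic carbon.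

Three measured steps at this place bear on it. Methyl in place of hydrogen gives an at least 2.6-fold lower number from compound 1 to compound 2 (0.42 log units; beyond the scatter), while trifluoromethoxy in place of hydrogen gives an at least 71-fold lower number from compound 1 to compound 3 (1.85 log units; beyond the scatter). Trifluoromethoxy in place of methyl gives a 27-fold lower number from compound 2 to compound 3 (1.42 log units; beyond the scatter). Among the measured compounds shown here, none of these steps tests trifluoromethyl itself, so the expectation is only that compound 4 keeps much of the gain seen in a 27-fold lower number from compound 2 to compound 3 (1.42 log units; beyond the scatter), but not all of it. The expected change in this assay is modest, an estimated 2.5-fold higher number from compound 3 to compound 4 (0.40 log units; beyond the scatter). For compound 4 the estimated value is 350 nM, with an expected range from 90 nM to 1500 nM.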

Compound 4, half-maximal inhibitory concentration: 20 nM
Compound 4: middle estimate off by 18-fold (1.24 log units), on the high side, and the stated range ends above it.
By their numbers in this assay, from the lowest: compound 4; then compound 3; then compound 2. At a limit, above all of these: compound 1.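

The result shows that the oxygen of trifluoromethoxy is not needed for a low number at this position, on an aromatic carbon ortho to a large group: in this assay, trifluoromethyl gives a 7.0-fold lower number from compound 3 to compound 4 (0.85 log units; beyond the scatter). Compared with methyl, the same group gives a 190-fold lower number from compound 2 to compound 4 (2.27 log units; beyond the scatter), which makes trifluoromethyl the best of the four groups shown at this place. The step from hydrogen, an at least 500-fold lower number from compound 1 to compound 4 (2.69 log units; beyond the scatter), is only a floor, as compound 1 gives a limit and not a number: the limit of > 10000 nM in this assay, at which 1 of the 4 values shown sits.

The compounds shown leave open how a chlorine atom, a nitrile or a methoxy group would compare with trifluoromethyl at this place. Going by these compounds, all four compounds also share one core, so whether trifluoromethyl gives a similar step on another core stays open.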